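This account rests on a few compounds, and the source may have more. Where it says the series, first, only, none or still open, it means among the compounds named here.

Among the compounds with values here, in an in vitro ADME assay on microsomes from liver (Homo sapiens) for pharmacokinetics, read by LC-MS, with a stated time of 10 min, tested at 1 uM (on this read-out higher numbers stand for fast clearance and lower numbers for slow clearance), three compounds built on one shared core have numbers so far. Compound 1 `Cc1ccc(NC(=O)[C@H]2CN(C)C[C@@H]2c2ccc(/C=C/C(=O)Nc3ccccc3N)cc2)cc1` gives 15 mL/min/kg, compound 2 `CN1C[C@H](C(=O)Nc2ccc(C#N)cc2)[C@@H](c2ccc(/C=C/C(=O)Nc3ccccc3N)cc2)C1` gives 1 mL/min/kg, and compound 3 `Cc1cccc(NC(=O)[C@H]2CN(C)C[C@@H]2c2ccc(/C=C/C(=O)Nc3ccccc3N)cc2)c1` gives 14 mL/min/kg. Compound 3 therefore stands level with compound 1 at the upper end of the three, with compound 2 far beneath both.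

Compound 4 `CN1C[C@H](C(=O)Nc2ccccc2F)[C@@H](c2ccc(/C=C/C(=O)Nc3ccccc3N)cc2)C1` keeps the core and differs from compound 3 in one place, on an amide-type nitrogen: 2-fluorophenyl in place of 3-methylphenyl on an amide-type nitrogen. Three measured steps offer guidance. The step of a 1.1-fold lower number from compound 1 to compound 3 (0.03 log units; within the scatter) stayed within the scatter, so swapping 4-methylphenyl for 3-methylphenyl changed little. The steps of a 15-fold lower number from compound 1 to compound 2 (1.18 log units; beyond the scatter) and a 14-fold higher number from compound 2 to compound 3 (1.15 log units; beyond the scatter) were both large, which shows that this group can matter, at least when 4-cyanophenyl is involved. Within the data shown here, no measured compound carries 2-fluorophenyl, so the guidance is indirect. A modest move towards slower clearance, without leaving the scatter, is expected, as an estimated 1.8-fold lower number from compound 3 to compound 4 (0.24 log units; within the scatter). The estimated clearance of compound 4 is 8 mL/min/kg, with an expected range of 3 mL/min/kg to 18 mL/min/kg.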

Compound 4, clearance: 10 mL/min/kg
Beside the measured number, compound 4's estimate is 1.3-fold (0.10 log units) below it; low and high end bracket the measured number.
By their numbers in this assay, from the lowest: compound 2; then compounds 4, 3 and 1 (each within the scatter of the next).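

In this assay, 2-fluorophenyl on the amide-type nitrogen joins the two methylphenyl groups, with a 1.4-fold lower number from compound 3 to compound 4 (0.15 log units; within the scatter) and a 1.5-fold lower number from compound 1 to compound 4 (0.18 log units; within the scatter), so replacing methyl with fluorine on this phenyl ring gives no change that can be told from the scatter. Within the data shown here, compound 2 stays apart from this group of three, as a 10-fold higher number from compound 2 to compound 4 (1.00 log units; beyond the scatter) shows, which leaves 4-cyanophenyl as the only group here with a clearly different clearance. No measurement shown accounts for these numbers.

From the compounds shown here alone, it remains open whether the low clearance of compound 2 belongs to the nitrile itself or to where it sits on the phenyl ring. Also open, going by these compounds, is how clearance would respond to a phenyl ring carrying an amine or a carboxylic acid at this position.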